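Clearance after swapping benzothiazolyl for indazolyl

The compounds below may be only part of what the source reports. "The series", "measured", "known", "first", "only" and "open" are said of these compounds alone.

- compound 1 `Nc1ccc(S(=O)(=O)N2CCN(c3ncc(C(O)(C(F)(F)F)C(F)(F)F)cc3Br)CC2)cn1`: 32 mL.min-1.g-1
- compound 2 `Nc1ccc(S(=O)(=O)N2CCN(c3ncc(C(O)(C(F)(F)F)C(F)(F)F)cc3-c3ccncc3)CC2)cn1`: 31 mL.min-1.g-1
- compound 3 `Nc1ccc(S(=O)(=O)N2CCN(c3ncc(C(O)(C(F)(F)F)C(F)(F)F)cc3-c3ccc4scnc4c3)CC2)cn1`: 147 mL.min-1.g-1

In an ADME assay (liver) for metabolic stability, with Liver microsome (Rattus norvegicus) as the target, using microsomes and NADPH, with a stated time of 30 min, tested at 1 uM (on this read-out lower numbers stand for slow clearance and higher numbers for fast clearance), compound 3 gives 147 mL.min-1.g-1, the highest of the three numbers. Compound 4 `Nc1ccc(S(=O)(=O)N2CCN(c3ncc(C(O)(C(F)(F)F)C(F)(F)F)cc3-c3ccc4[nH]ncc4c3)CC2)cn1` differs from it in one place: 1H-indazol-5-yl in place of 1,3-benzothiazol-5-yl on an aromatic carbon. Two measured steps show what the leaving group has done so far: a 4.6-fold higher number from compound 1 to compound 3 (0.66 log units; beyond the scatter) and a 4.7-fold higher number from compound 2 to compound 3 (0.68 log units; beyond the scatter). Exchanging bromo for pyridin-4-yl gave only a 1.0-fold lower number from compound 1 to compound 2 (0.01 log units; within the scatter). Within the data shown here, no measured step exchanges 1,3-benzothiazol-5-yl for another group of two rings, so the evidence is indirect. Compound 4 keeps two rings, and only a partial return toward the lower numbers is expected. The expected change is a 1.7-fold lower number from compound 3 to compound 4 (0.24 log units; within the scatter). Compound 4 is estimated at 85 mL.min-1.g-1, with an expected range of 35 mL.min-1.g-1 to 190 mL.min-1.g-1.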

Compound 4, intrinsic clearance in microsomes: 88 mL.min-1.g-1
Compound 4: middle estimate off by 1.0-fold (0.02 log units), on the low side; measured number inside the range.
By their numbers in this assay, from the lowest: compounds 2 and 1 (each within the scatter of the next); then compounds 4 and 3 (each within the scatter of the next).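

In this assay, 1H-indazol-5-yl and 1,3-benzothiazol-5-yl cannot be told apart at this position (a 1.7-fold lower number from compound 3 to compound 4 (0.22 log units; within the scatter)), as the step lies within the scatter. Both pyridin-4-yl (a 2.8-fold higher number from compound 2 to compound 4 (0.45 log units; beyond the scatter)) and bromo (a 2.8-fold higher number from compound 1 to compound 4 (0.44 log units; beyond the scatter)) give way to a higher number with 1H-indazol-5-yl, so the higher clearance at this position is not confined to 1,3-benzothiazol-5-yl. Nothing here explains these numbers. Open, on these data alone, is how a plain phenyl ring or an amine at this position would read, and whether other attachment points on the indazole give the same number.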